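This account rests on a few compounds, and the source may have more. Where it says the series, first, only, none or still open, it means among the compounds named here.

The measured compounds:
compound 1, `Nc1ccccc1NC(=O)c1c(O)c2ccccc2oc1=O`, 57%
compound 2, `NCCCCCCCCNC(=O)c1c(O)c2ccccc2oc1=O`, 48%

Both compounds were tested in a functional assay on the whole organism (strain Fisher 344) for inhibition, with Rattus norvegicus as the target, read by paw edema, with a stated time of 3.5 h, at a dose of 0.01 mmol/kg by the intraperitoneal route; on this read-out higher numbers stand for more inhibition at the one dose given (going by the name of the read-out) and lower numbers for less inhibition. Compound 1 gives 57% and compound 2 gives 48%; the number for compound 2 is the lower of the two, but the gap to compound 1 lies within the usual scatter of this measurement, so the two compounds are not separated on this read-out.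

Compound 3, `NCCNC(=O)c1c(O)c2ccccc2oc1=O`, has not yet been tested. Relative to compound 2 the change is amino in place of 6-aminohexyl on a saturated chain carbon, two bonds along the chain from an amide-type nitrogen. The shared core, the amide link and the terminal amine are kept; only the length of the saturated chain that carries the terminal amine is shortened.

Among the compounds with values here, with only two measured compounds, neither of which differs from the other in one place, there is no measured step on which to rest a direction. Compound 3 is expected to give a step of a number 2 percentage points higher from compound 2 to compound 3 (within the scatter) in this assay, that is, no change beyond the scatter. Compound 3 is therefore estimated at 50%, with a range from 35% to 65%.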

Compound 3, a percentage reported as inhibition, in the whole organism at one dose (the size of the read-out at that dose, not a potency): 59%
For compound 3 the middle estimate is 9 percentage points below the measured one, and the stated range covers the measured number.
By their numbers in this assay, from the lowest: compounds 2, 1 and 3 (each within the scatter of the next, the first and the last beyond it).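

In this assay, within the data shown here, the change to amino in place of 6-aminohexyl, on a saturated chain carbon, two bonds along the chain from an amide-type nitrogen, gives a number 11 percentage points higher from compound 2 to compound 3 (beyond the scatter) and so provides the first measured evidence that the length of this saturated chain can affect the read-out, with the shorter chain giving the higher inhibition at the one dose given. A second comparison, 2-aminoethyl in place of 2-aminophenyl on an amide-type nitrogen, gives a number 2 percentage points higher from compound 1 to compound 3 (within the scatter) and does not separate the two compounds on this read-out. Nothing measured here gives a reason for either step.

With only two chain lengths shown, the compounds leave open whether inhibition changes steadily with length or whether a chain of intermediate length, such as 4-aminobutyl, would give a different result. They also leave open what would happen with a hydroxyl or a carboxylic acid in place of the terminal amine.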